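Swapping a bromophenyl for dichlorophenyl on a weakly cytotoxic core

A few compounds are considered here, and "the series" means these few. Any claim that something is new, unique, unknown or untested is made for them only; others in the source may bear on it.

Measured compounds:
compound 1: `Clc1ccc(Cc2nn3cc(-c4ccc(Br)cc4)nc3s2)cc1`
compound 2: `Cc1ccc(-c2cn3nc(Cc4ccc(Cl)cc4)sc3n2)cc1`
compound 3: `Clc1ccc(Cc2nn3c(Br)c(-c4ccc(Br)cc4)nc3s2)cc1`

In an ADME assay on CCRF-CEM cells (Homo sapiens) for cytotoxicity, with a stated time of 72 h (on this read-out higher numbers stand for weaker inhibition and lower numbers for stronger inhibition), compound 1 gives > 250000 nM, which is a limit of the assay rather than a number. Compound 2 likewise gives > 250000 nM, again a limit. Going by the values given here, compound 3 gives 238000 nM, the only actual number among the three. Compounds 1 and 2 sit at the limit (the limit of > 250000 nM in this assay, at which 2 of the 3 values shown sit). The step of an at least 1.0-fold lower number from compound 1 to compound 3 (0.02 log units; that floor lies within the scatter) lies within the scatter, and the step that the two limits leave unreadable from compound 1 to compound 2 cannot be read because both ends are limits.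

Compound 4 `Clc1ccc(Cc2nn3c(Br)c(-c4ccc(Cl)cc4Cl)nc3s2)cc1` differs from compound 3 by 2,4-dichlorophenyl in place of 4-bromophenyl on an aromatic carbon. Among the compounds with values here, no measured step concerns a change of this kind: the one readable step alters a different group and is within the scatter, and the other is unreadable. Compound 4 is therefore expected to show no step beyond the scatter, a 1.0-fold higher number from compound 3 to compound 4 (0.00 log units; within the scatter). The estimate for compound 4 is 240000 nM, within a range from 100000 nM to 600000 nM, with a real chance that only a limit is reported.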

Compound 4, half-maximal inhibitory concentration: 106000 nM
Compound 4: the middle estimate sits 2.3-fold (0.35 log units) above what was measured, within the range that was stated.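

Going by these compounds alone, replacing 4-bromophenyl with 2,4-dichlorophenyl gives a 2.2-fold lower number from compound 3 to compound 4 (0.35 log units; beyond the scatter), the first step beyond the scatter in this assay. The earlier steps shown here could not show this: one lies within the scatter and concerns a different place, and the other cannot be read. Compound 4 thus shows that the aryl group at this position can shift the read-out, if only modestly, on a core that otherwise gives little to compare.

This single step changes the halogen and the substitution pattern together, so it leaves open whether the chlorines, their placement or both account for the shift, and how an amine or a carboxylic acid on this phenyl ring would read. Comparison across the set also remains narrow: the limit of > 250000 nM in this assay, at which 2 of the 4 values shown sit.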